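A few compounds are considered here, and "the series" means these few. Any claim that something is new, unique, unknown or untested is made for them only; others in the source may bear on it.

Measured compounds:
compound 1, `CCc1nc2ccccc2n1CCCCOc1cccc(C)c1`, 19 uM
compound 2, `CCc1nc2ccccc2n1CCCCOc1ccc(C)c(C)c1`, 14 uM
compound 3, `CCc1nc2ccc(C)cc2n1CCCOc1ccc(C)cc1`, 15 uM

All three numbers come from an ADME assay on Vero cells (Chlorocebus sabaeus) for cytotoxicity, read by luminescence, with a stated time of 2 days (a higher number here means that more compound is tolerated, a lower number that less compound is tolerated), and none of them stands apart from the others beyond the usual scatter. Compound 4, `CCc1nc2ccc(C)cc2n1CCCOc1ccc(C)c(C)c1`, is not yet measured.

Compound 1 and compound 2 differ by methyl in place of hydrogen on an aromatic carbon, and that single change gave a 1.4-fold lower number from compound 1 to compound 2 (0.13 log units; within the scatter). Compound 3 and compound 4 differ by methyl in place of hydrogen on an aromatic carbon. This is the same kind of change, not the same: in both the entering methyl sits ortho to a methyl group, but in compound 3 the place is meta to a large group, whereas in compound 1 it is para to a large group. The difference between the core of compound 1 and the core of compound 3 is not broken down here; their two values simply lie within the scatter of each other.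

For compound 4 in this assay the expected step is a 1.3-fold lower number from compound 3 to compound 4 (0.10 log units; within the scatter). Among the measured compounds shown here, this rests on a 1.4-fold lower number from compound 1 to compound 2 (0.13 log units; within the scatter), the one measured instance of this kind of change, with the differing place around the entering methyl widening the range. Compound 4 is estimated at 12 uM, between 6 uM and 25 uM.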

Compound 4, half-maximal toxic concentration: 7.3 uM
Compound 4: middle estimate off by 1.6-fold (0.22 log units), on the high side; the measured number falls inside the stated range.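

In this assay, among the compounds shown here, methyl in place of hydrogen on an aromatic carbon gave a 2.1-fold lower number from compound 3 to compound 4 (0.31 log units; beyond the scatter), and the two instances of this change do not differ: the same change on two cores in this assay, a 1.4-fold lower number (0.13 log units; within the scatter) from compound 1 to compound 2 and a 2.1-fold lower number (0.31 log units; beyond the scatter) from compound 3 to compound 4, 1.5-fold (0.18 log units) apart, within the scatter of two such steps On these two cores the change can therefore be read as a single step size, although only the step on the core of compound 3 lies beyond the scatter. Two instances do not show that the step will hold on other cores, and they cannot show whether the different surroundings of the entering methyl play any part.

The compounds shown leave open whether a chlorine, a methoxy group or a carboxylic acid at the same place on the aromatic ring would give a step of similar size in this assay. Also open, as far as these compounds go, is whether the methyl step would persist with an amine added to the chain that joins the two aromatic parts.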